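This account rests on a few compounds, and the source may have more. Where it says the series, first, only, none or still open, it means among the compounds named here.

Working notes on a small set of nucleoside analogues assessed in a toxicity assay on Huh-7 cells (Homo sapiens) for cytotoxicity, with a stated time of 3 days; on this read-out lower numbers stand for higher toxicity in this test and higher numbers for lower toxicity in this test. Compound 1 `C[C@@]1(O)[C@H](O)[C@@H](CO)O[C@H]1n1cc(-c2ccco2)c2c(N)ncnc21` gives 49600 nM in this assay. Compound 2 `C[C@@]1(O)[C@H](O)[C@@H](CO)O[C@H]1n1cc(-c2cccs2)c2c(N)ncnc21` carries thiophen-2-yl in place of furan-2-yl on an aromatic carbon and gives 48100 nM in this assay. The measured step is a 1.0-fold lower number from compound 1 to compound 2 (0.01 log units; within the scatter).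

Compound 3 `Nc1ncnc2c1c(-c1ccco1)cn2[C@H]1C[C@H](O)[C@@H](CO)O1` rests on a different core; the difference between the core of compound 3 and the core of compound 1 is not broken down here. In this assay compound 3 gives only a limit, > 44000 nM. This is the limit of > 44000 nM in this assay, at which 1 of the 3 values shown sits.

Compound 4 `Nc1ncnc2c1c(-c1cccs1)cn2[C@H]1C[C@H](O)[C@@H](CO)O1` has not yet been measured in this assay. It carries thiophen-2-yl in place of furan-2-yl on an aromatic carbon. This is the same kind of change as that from compound 1 to compound 2, the place differing only in that the ring atom bears a group of 8 heavy atoms in the one case and a large group in the other.

The step from compound 3 to compound 4 is expected to be a step that the limit leaves unreadable from compound 3 to compound 4, set beside the measured 1.0-fold lower number from compound 1 to compound 2 (0.01 log units; within the scatter); the expectation rests on that measured step, which stayed within the scatter. Compound 4 is therefore expected to give 50000 nM in this assay, estimated between 30000 nM and 100000 nM, and a limit rather than a number is a likely outcome.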

Compound 4, half-maximal cytotoxic concentration: > 44000 nM
Compound 4: a limit, no number; the forecaster's own chance of this, stated with the estimate: 60%; the middle value lies beyond the limit too.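

In this assay, compound 3 and compound 4 each give only a limit, so no step can be read between them: the limit of > 44000 nM in this assay, at which 2 of the 4 values shown sit.

The compounds shown leave open whether thiophen-2-yl in place of furan-2-yl on the core of compound 3 matters as little as it does on the core of compound 1, where the step stayed within the scatter.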